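Ethyl on the amide nitrogen of compound 2

A few compounds are considered here, and "the series" means these few. Any claim that something is new, unique, unknown or untested is made for them only; others in the source may bear on it.

Measured compounds:
compound 1, `CCCC(=O)C1=C(C)NC(=O)NC1c1ccsc1`: 9%
compound 2, `CC1=C(C(N)=O)C(c2ccsc2)NC(=O)N1`: 1%

Both numbers come from an assay on membranes from HEK293 cells for displacement of a labelled ligand from adenosine receptor A2b (Homo sapiens), read by scintillation counting, with a stated time of 30 min, tested at 1 uM; on this read-out higher numbers stand for more inhibition at the one concentration tested (going by the name of the read-out) and lower numbers for less inhibition. On the numbers shown, compound 2 has the lower of the two readings, and compound 1 is its only neighbour; the single measured step, a number 8 percentage points lower from compound 1 to compound 2 (within the scatter), lies within the scatter, so the two compounds cannot really be told apart and both sit near the bottom of the scale.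

Compound 3, `CCNC(=O)C1=C(C)NC(=O)NC1c1ccsc1`, is the next step from compound 2. The change is ethyl in place of hydrogen on an amide-type nitrogen. Going by the values given here, no measured step makes exactly this change. Among the compounds with values here, the only step that exists touches the same carbonyl group, exchanging propyl for amino on its carbon, and it stayed within the scatter; that is the only guidance available, and it points to no large movement in this assay when the carbonyl region is altered.

For compound 3 the expected step is therefore a number 4 percentage points higher from compound 2 to compound 3 (within the scatter), nothing beyond the scatter. The estimate for compound 3 in this assay is 5%, with a range from -6% to 16%.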

Compound 3, a percentage reported as inhibition, at one concentration (the size of the read-out at that concentration, not a potency): 1%
Estimate against measurement, compound 3: 4 percentage points above, within the range that was stated.
By their numbers in this assay, from the lowest: compounds 2, 3 and 1 (each within the scatter of the next).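

Going by these compounds alone, compound 3 gives the first look at the amide-type nitrogen itself, and in this assay ethyl in place of hydrogen there gives no change at the digits printed from compound 2 to compound 3 (within the scatter) at the one concentration tested. Exchanging propyl on the carbonyl carbon for ethylamino gives a number 8 percentage points lower from compound 1 to compound 3 (within the scatter) and so cannot be told apart either, which means that propyl, amino and ethylamino on this carbonyl carbon all read alike near the bottom of the scale in these three compounds. No measurement shown explains why adding ethyl at this nitrogen leaves the reading where it stands.

With all three readings this low, the data cannot say whether any change at this position could raise the inhibition, so the flat result describes only these small groups. Going by these compounds, whether a longer chain or a benzyl group on the amide-type nitrogen, or a carboxylic acid in place of the amide on the shared core, would move the number beyond the scatter remains open.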